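The compounds below may be only part of what the source reports. "The series", "measured", "known", "first", "only" and "open" are said of these compounds alone.

Measured compounds:
- compound 1, `O=C(Nc1nnc(-c2cccc(O)c2O)s1)C1CCCCC1`: 70300 nM
- compound 2, `CC(=O)Nc1nnc(-c2ccc(O)c(O)c2)s1`: 58600 nM
- compound 3, `O=C(Nc1nnc(-c2ccc(O)c(O)c2)s1)C1CCCCC1`: 24000 nM

These three share a core and were tested in an ADME assay on MRC5 cells (Homo sapiens) for cytotoxicity, read by MTT assay, with a stated time of 72 h; on this read-out lower numbers stand for stronger inhibition and higher numbers for weaker inhibition. Compound 1 gives the highest number of the three, but its gap to compound 2 is within the scatter, so the two cannot be ordered; compound 3 sits clearly lower than compound 1. The unmeasured compound 4, `CC(=O)Nc1nnc(-c2cccc(O)c2O)s1`, differs from compound 1 at one point: methyl in place of cyclohexyl on a carbonyl carbon. The same kind of change has been measured once, in the opposite direction, between compounds that carry the other arrangement of hydroxyl groups: a 2.4-fold lower number from compound 2 to compound 3 (0.39 log units; beyond the scatter). Reversing that change on compound 1 should therefore, if the core behaves alike, give a step of similar size towards a higher number. Since compound 1 already stands high, the expected result for compound 4 would lie further up, and it cannot be ruled out that this assay reports only a limit rather than a number. The expected step is a 2.3-fold higher number from compound 1 to compound 4 (0.36 log units; beyond the scatter). Compound 4 is thus estimated at 160000 nM, with a plausible range from 75000 nM to 350000 nM.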

Compound 4, half-maximal inhibitory concentration: 156000 nM
Compound 4: middle estimate off by 1.0-fold (0.01 log units), on the high side, and the stated range covers the measured number.
By their numbers in this assay, from the lowest: compound 3; then compounds 2 and 1 (each within the scatter of the next); then compound 4.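

Putting methyl in place of cyclohexyl on the carbonyl carbon of the core of compound 1 moves the number upwards in this assay (a 2.2-fold higher number from compound 1 to compound 4 (0.35 log units; beyond the scatter)). Until now, this swap had been read on only one arrangement of the hydroxyl groups, so it could not be told whether its effect belonged to that arrangement alone. Now that it has been read on both arrangements, the compound with cyclohexyl gives the lower number each time, and the two steps are practically the same size: the same change on two cores in this assay, a 2.4-fold lower number (0.39 log units; beyond the scatter) from compound 2 to compound 3 and a 2.2-fold lower number (0.35 log units; beyond the scatter) from compound 4 to compound 1, 1.1-fold (0.04 log units) apart, within the scatter of two such steps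

Across these four compounds, then, the effect of the swap at this place can be treated as the same on either core, so it can be carried from one to the other without a correction. The compounds shown hold only methyl and cyclohexyl on this carbonyl carbon, so they cannot tell where a longer chain such as butyl, a phenyl ring or an amine would fall relative to those two. They also leave open why cyclohexyl gives the lower number, and whether the same swap would behave alike on a core with the hydroxyl groups replaced by methoxy groups.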